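Chain extension at the alkyne ester of compound 1

This account rests on a few compounds, and the source may have more. Where it says the series, first, only, none or still open, it means among the compounds named here.

Compound 1 `C#CCOC(=O)Cn1cnc2c1c(=O)n(C)c(=O)n2C` is the smallest member of this set. In a functional assay on MCF7 cells (Homo sapiens) for cytotoxicity, read by MTT assay, with a stated time of 48 h (on this read-out higher numbers stand for weaker inhibition and lower numbers for stronger inhibition), compound 1 gives 33900 nM, the highest number among the three measured. The two larger conjugates sit well below it: compound 2 `CCn1c(=O)ccn(C2OC(Cn3cc(COC(=O)CNC(=O)Cn4cnc5c4c(=O)n(C)c(=O)n5C)nn3)C(O)C2O)c1=O` gives 2100 nM in this assay, and compound 3 `Cn1c(=O)c2c(ncn2CC(=O)OCCc2cn(CC3OC(n4ccc(=O)[nH]c4=O)C4OC(C)(C)OC34)nn2)n(C)c1=O` gives 2400 nM. Both gaps from compound 1 lie beyond the scatter, while compounds 2 and 3 fall within scatter of each other, so no order is drawn between those two.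

Compound 4 `C#CCCOC(=O)Cn1cnc2c1c(=O)n(C)c(=O)n2C` has not yet been measured. It differs from compound 1 in one place: propargyl in place of ethynyl on a saturated chain carbon bound to an oxygen next to a carbonyl group. The shared core of compound 1 is untouched, the ester is kept, and only the chain on the saturated chain carbon bound to an oxygen next to a carbonyl group is lengthened.

Going by the values given here, no step between measured compounds isolates a change of this kind, so the expectation rests on compound 1 alone. A change of this kind is expected to move the number little, and the step from compound 1 to compound 4 is estimated as a 1.1-fold lower number from compound 1 to compound 4 (0.05 log units; within the scatter), within the scatter and in no firm direction. Compound 4 is therefore expected to give about 30000 nM in this assay, with a range of 12000 nM to 80000 nM.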

Compound 4, half-maximal inhibitory concentration: 56300 nM
Beside the measured number, compound 4's estimate is 1.9-fold (0.27 log units) below it; the measured number falls inside the stated range.
By their numbers in this assay, from the lowest: compounds 2 and 3 (each within the scatter of the next); then compounds 1 and 4 (each within the scatter of the next).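

In this assay, going by these compounds alone, the first step that changes only this position reads a 1.7-fold higher number from compound 1 to compound 4 (0.22 log units; within the scatter), with propargyl replaced by but-3-yn-1-yl on a saturated chain carbon bound to an oxygen next to a carbonyl group. Compounds 1 and 4 therefore cannot be ordered, and this single extension, with the triple bond and the ester kept, leaves no change that can be told from the usual scatter of the assay. This is a reading of one pair only, and no accompanying measurement bears on why the two compounds read alike.

Going by these compounds, whether the position stays this flat remains open: a longer chain, or an amine or a carboxylic acid at the end of the chain in place of the triple bond, could show whether other groups here move the number beyond the scatter. On these data alone, compounds 2 and 3 differ from compound 1 in more than one place, so how far a change at this position accounts for their numbers remains open as well.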